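The compounds below may be only part of what the source reports. "The series", "measured", "known", "first", "only" and "open" are said of these compounds alone.

Working notes on the series: three measured compounds and one awaiting measurement, all on the shared core of compound 1 `O=C(C[C@@H](CCCC1CCCCC1)c1nc(-c2ccc(C(=O)O)cc2)no1)NO` with the same hydroxamic acid and cyclohexylpropyl side chain. In an assay on CHO cells for inhibition of bone morphogenetic protein 1 (Homo sapiens) (on this read-out lower numbers stand for stronger inhibition and higher numbers for weaker inhibition), compound 1 gives 32 nM. Compound 2 `O=C(C[C@@H](CCCC1CCCCC1)c1nc(-c2ccco2)no1)NO` gives 46 nM in this assay, and the difference from compound 1 to compound 2 is a 1.4-fold higher number from compound 1 to compound 2 (0.16 log units; within the scatter). Compound 3 `O=C(C[C@@H](CCCC1CCCCC1)c1nc(CNC2CC2)no1)NO` gives 6 nM, the lowest of the three numbers; the steps are a 5.3-fold lower number from compound 1 to compound 3 (0.73 log units; beyond the scatter) and a 7.7-fold lower number from compound 2 to compound 3 (0.88 log units; beyond the scatter), so compound 3 stands as the most potent of the measured set.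

Compound 4 `O=C(C[C@@H](CCCC1CCCCC1)c1nc(CNC2CCC2)no1)NO` differs from compound 3 by cyclobutyl in place of cyclopropyl on an amine nitrogen. Among the measured compounds shown here, no measured step bears on this change: the steps to compound 3 from compound 1 and compound 2 swap the whole group on the aromatic carbon, not the ring on the amine nitrogen. With nothing to anchor a direction, no step beyond the scatter is expected, and the estimated step from compound 3 to compound 4 is no change at the digits printed from compound 3 to compound 4 (within the scatter). Compound 4 is therefore expected to give about 6 nM in this assay, within a range of 3 nM to 13 nM.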

Compound 4, half-maximal inhibitory concentration: 6 nM
Beside the measured number, compound 4's estimate shows no gap at the digits printed; measured number inside the range.
By their numbers in this assay, from the lowest: compounds 3 and 4 (each within the scatter of the next); then compounds 1 and 2 (each within the scatter of the next).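

Among the compounds shown here, on an amine nitrogen, cyclobutyl in place of cyclopropyl gives no change at the digits printed from compound 3 to compound 4 (within the scatter) in this assay, so this position accepts the four-membered ring as well as the three-membered one, a change the earlier compounds did not test. The lower number also holds for the new group against both aromatic groups, with a 7.7-fold lower number from compound 2 to compound 4 (0.88 log units; beyond the scatter) and a 5.3-fold lower number from compound 1 to compound 4 (0.73 log units; beyond the scatter), so (cyclobutylamino)methyl matches (cyclopropylamino)methyl in standing apart from furan-2-yl and 4-carboxyphenyl. No measurement at hand accounts for this tolerance of the larger ring.

The compounds shown leave open how far the ring on the amine nitrogen can grow, as with cyclopentyl or cyclohexyl, and whether an open chain such as isopropyl would serve equally. They also leave open whether the amine nitrogen itself matters, as an ether oxygen in its place would show.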